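The compounds below may be only part of what the source reports. "The series", "measured", "known", "first", "only" and "open" are said of these compounds alone.

Measured compounds:
- Compound 1, `O=C(Oc1ccc(-c2cncn2C2CCN(C(=O)c3ccc(Cl)c(C(F)(F)F)c3)CC2)cc1)c1cccs1`: > 10000 nM
- Compound 2, `CCN(CC)C(=O)c1cccc(S(=O)(=O)Oc2ccc(-c3cncn3C3CCN(C(=O)c4ccc(Cl)c(C(F)(F)F)c4)CC3)cc2)c1`: 202 nM
- Compound 3, `COc1ccc(C(=O)N2CCC(n3cncc3-c3ccc(OS(=O)(=O)c4cccc5cnccc45)cc3)CC2)cc1`: 77 nM

All three were tested in an assay on HEK293 cells for antagonist activity at P2X purinoceptor 7 (Homo sapiens), read by fluorescence, with a stated time of 2 h; on this read-out higher numbers stand for weaker inhibition and lower numbers for stronger inhibition. For compound 1 the result > 10000 nM is a limit of the assay rather than a number, as noted in the limit of > 10000 nM in this assay, at which 1 of the 3 values shown sits. Among the two numbers that were obtained, compound 3 has the lowest one, 77 nM, and the gap to compound 2, which gave 202 nM, is beyond the usual scatter of this assay. Compound 3 therefore stands as the stronger inhibitor of the two measured here.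

Compound 4, `CN(C)c1ccc(C(=O)N2CCC(n3cncc3-c3ccc(OS(=O)(=O)c4cccc5cnccc45)cc3)CC2)cc1`, has not yet been measured. It differs from compound 3 in one place only: dimethylamino in place of methoxy on an aromatic carbon. The rest of the molecule, including the shared core and the sulfonate-linked ring system, is unchanged. For the measured compounds named here, no pair of measured compounds shows what this particular swap does, so the expectation rests on the small size of the change alone. The step from compound 3 to compound 4 is expected to be modest, with no clear direction, and most likely within the scatter, so a 1.0-fold higher number from compound 3 to compound 4 (0.02 log units; within the scatter) is the estimate. On that basis compound 4 is expected to give about 80 nM in this assay, somewhere between 25 nM and 250 nM.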

Compound 4, half-maximal inhibitory concentration: 0.11 nM
Compound 4: middle estimate off by 730-fold (2.86 log units), on the high side; the measured number lies below the stated range.
By their numbers in this assay, from the lowest: compound 4; then compound 3; then compound 2. At a limit, above all of these: compound 1.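

Replacing the 4-methoxyphenyl group with 4-(dimethylamino)phenyl, on an aromatic carbon para to a large group, gives a 700-fold lower number from compound 3 to compound 4 (2.85 log units; beyond the scatter) in this assay. For the compounds shown here, this is the first step that can be read as a single change. The earlier compounds shown here differ from one another in more than one place. The step shows that this position is highly sensitive: one exchange of a small group, with the shared core and the sulfonate-linked ring system unchanged, moves the number far beyond the scatter. Nothing in the data shown accounts for the size of this step.

The compounds shown leave open how other groups at the same position would behave, such as a plain hydrogen, a primary amine, methylamino or the longer diethylamino, so it cannot yet be said what feature of dimethylamino matters. Going by these compounds alone, it also remains open whether the same exchange would have a similar effect with a different group on the sulfonate, such as the one in compound 2.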